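The source may hold more compounds than are shown below. What is called first, only, known or untested is meant among the compounds shown, and "the series" means these compounds.

Within the data shown here, compound 2 `N/C(=N/NC(CC(=O)c1ccc(-n2ccnc2)cc1)c1cccc(F)c1)c1ccccn1` gives the lowest of the two numbers so far in an ADME assay on Vero cells (Chlorocebus sabaeus) for cytotoxicity, read by MTT assay, with a stated time of 72 h (on this read-out lower numbers stand for higher toxicity in this test and higher numbers for lower toxicity in this test), at 26500 nM. Among the measured compounds shown here, compound 1 `N/C(=N/NC(CC(=O)c1ccc(-n2ccnc2)cc1)c1ccc(F)cc1)c1ccccn1` gives 78800 nM in this assay, and the single measured step, a 3.0-fold lower number from compound 1 to compound 2 (0.47 log units; beyond the scatter), moves the number down. Compound 3 `N/C(=N/NC(CC(=O)c1ccc(-n2ccnc2)cc1)c1ccc(Cl)cc1Cl)c1ccccn1` differs from compound 2 by 2,4-dichlorophenyl in place of 3-fluorophenyl on a saturated chain carbon bound to an amine nitrogen and a saturated chain carbon. For the measured compounds named here, the one measured step concerns a different change, so it bears only loosely on this one; for compound 3 a step of a 1.3-fold lower number from compound 2 to compound 3 (0.12 log units; within the scatter) in this assay is expected, within the scatter. Compound 3 is therefore estimated at 20000 nM in this assay, with a range from 7000 nM to 60000 nM.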

Compound 3, half-maximal cytotoxic concentration: 27800 nM
Compound 3: the middle estimate sits 1.4-fold (0.14 log units) below what was measured; measured number inside the range.
By their numbers in this assay, from the lowest: compounds 2 and 3 (each within the scatter of the next); then compound 1.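

In this assay, the step to the 2,4-dichlorophenyl group, a 1.0-fold higher number from compound 2 to compound 3 (0.02 log units; within the scatter), leaves compound 3 level with compound 2, although two chlorines replace one fluorine at this position. The second step, a 2.8-fold lower number from compound 1 to compound 3 (0.45 log units; beyond the scatter), shows that a second replacement of the 4-fluorophenyl group of compound 1 also gives a lower number, so compound 1 stands alone among the three. No measurement offered here accounts for this.

Going by these compounds, it remains open how an unsubstituted phenyl, a 4-chlorophenyl or a 4-methoxyphenyl group would read at this position.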